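A few compounds are considered here, and "the series" means these few. Any claim that something is new, unique, unknown or untested is made for them only; others in the source may bear on it.

Measured compounds:
Compound 1 `Cc1nc2ccccc2c(=O)n1NC(=O)NC1CCCCC1` — 88.6%
Compound 2 `Cc1nc2ccccc2c(=O)n1NC(=O)NC(C)(C)C` — 82.5%

In a functional assay on the whole organism (strain Sprague-Dawley) for inhibition, with Rattus norvegicus as the target, read by paw edema, with stated times of 30 min and 3 h, at a dose of 80 mg/kg by the oral route (on this read-out lower numbers stand for less inhibition and higher numbers for more inhibition at the one dose given (going by the name of the read-out)), compound 1 gives 88.6% and compound 2 gives 82.5%. Compound 2 holds the lower of the two numbers, but the step of a number 6.1 percentage points lower from compound 1 to compound 2 (within the scatter) lies within the scatter, so the two values cannot be ordered.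

Compound 3 `CC(C)(C)NC(=O)Nn1c(CO[N+](=O)[O-])nc2ccccc2c1=O` differs from compound 2 at another place: nitrooxy in place of hydrogen on a saturated chain carbon bound to an aromatic carbon. Within the data shown here, no measured step touches this part of the molecule; the single known step, tert-butyl in place of cyclohexyl on an amide-type nitrogen, was small and sits elsewhere. There is therefore nothing in the two measured compounds that points to a change beyond the scatter in either direction in this assay for compound 3, and the estimate leans on compound 2 alone because of 82.5%.

Compound 3 is expected to give 78% in this assay, within 60% to 92%. The step this expectation implies is a number 4.5 percentage points lower from compound 2 to compound 3 (within the scatter).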

Compound 3, a percentage reported as inhibition, in the whole organism at one dose (the size of the read-out at that dose, not a potency): 70.6%
For compound 3 the middle estimate is 7.4 percentage points above the measured one; measured number inside the range.
By their numbers in this assay, from the lowest: compound 3; then compounds 2 and 1 (each within the scatter of the next).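

In this assay the saturated chain carbon bound to an aromatic carbon proves to be a place where a change can be read: nitrooxy in place of hydrogen gives a number 11.9 percentage points lower from compound 2 to compound 3 (beyond the scatter) and so clears the scatter, which the earlier step on the amide-type nitrogen did not. The change from methyl to (nitrooxy)methyl therefore costs some inhibition at the one dose given, though compound 3 still reaches 70.6% in this read-out. No available evidence accounts for this drop.

The compounds shown leave open whether the drop belongs to the nitrooxy group itself or would come with other groups on this carbon: none carries a hydroxyl group or an amine there. Also open, as far as these compounds go, is whether the same change would give a like step with cyclohexyl rather than tert-butyl on the amide-type nitrogen.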